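Aryl replacement on the imidazole nitrogen of the chromone series

The source may hold more compounds than are shown below. What is called first, only, known or untested is meant among the compounds shown, and "the series" means these compounds.

Measured compounds:
compound 1 `Cc1cc2occ(-c3nc(-c4ccccc4)c(-c4ccccc4)n3-c3ccc([N+](=O)[O-])cc3)c(=O)c2cc1Cl` — 3130 nM
compound 2 `COc1ccccc1-n1c(-c2coc3cc(C)c(Cl)cc3c2=O)nc(-c2ccccc2)c1-c1ccccc1` — 12500 nM
compound 3 `Cc1cc2occ(-c3nc(-c4ccccc4)c(-c4ccccc4)n3-c3cccc([N+](=O)[O-])c3)c(=O)c2cc1Cl` — 6250 nM

All three compounds were tested in a functional assay on A549 cells (Homo sapiens) for inhibition, read by MTT assay, with a stated time of 72 h; on this read-out lower numbers stand for stronger inhibition and higher numbers for weaker inhibition. Compound 1 gives the lowest number of the three; the gap to compound 3 lies within the scatter, while the gap to compound 2 lies beyond it. The measured steps are a 4.0-fold higher number from compound 1 to compound 2 (0.60 log units; beyond the scatter) and a 2.0-fold higher number from compound 1 to compound 3 (0.30 log units; within the scatter), so exchanging 4-nitrophenyl for 2-methoxyphenyl carried a modest penalty, whereas shifting the nitro group to the 3-position changed little.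

Compound 4 `Cc1ccc(-n2c(-c3coc4cc(C)c(Cl)cc4c3=O)nc(-c3ccccc3)c2-c2ccccc2)cc1` is not yet measured. It differs from compound 1 as follows: methyl in place of nitro on an aromatic carbon. For the measured compounds named here, no measured pair covers methyl in place of nitro directly. The step from compound 1 to compound 2 shows that leaving the 4-nitrophenyl group can raise the number, and the step from compound 1 to compound 3 shows tolerance of a repositioned nitro group. A modest rise is therefore expected, a 1.9-fold higher number from compound 1 to compound 4 (0.28 log units; within the scatter). The estimate for compound 4 in this assay is 6000 nM, with a range from 2500 nM to 15000 nM.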

Compound 4, half-maximal inhibitory concentration: 12500 nM
Compound 4: the middle estimate sits 2.1-fold (0.32 log units) below what was measured; the range from low to high includes it.
By their numbers in this assay, from the lowest: compounds 1, 3, 2 and 4 (each within the scatter of the next, the first and the last beyond it).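

In this assay, methyl in place of nitro at the same place on the ring gives a 4.0-fold higher number from compound 1 to compound 4 (0.60 log units; beyond the scatter) and so shows that the nitro group cannot be swapped for methyl here without a modest penalty. Against the other two aryl groups the picture is flatter, with a 2.0-fold higher number from compound 3 to compound 4 (0.30 log units; within the scatter) and no change at the digits printed from compound 2 to compound 4 (within the scatter), so 4-methylphenyl cannot be told apart from 3-nitrophenyl or 2-methoxyphenyl, and only compounds 2 and 4 lie beyond the scatter from compound 1. Nothing shown accounts for this step.

The compounds shown leave open how an amine, a nitrile or a carboxylic acid would read at this place on the ring. They also leave open whether a plain phenyl on the imidazole nitrogen would sit nearer compound 1 or compound 4.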